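The source may hold more compounds than are shown below. What is called first, only, known or untested is meant among the compounds shown, and "the series" means these compounds.

In a functional assay on LoVo cells (Homo sapiens) for inhibition, read by colorimetric assay and MTT assay, with a stated time of 72 h (a lower number here means a stronger inhibitor, a higher number a weaker inhibitor), compound 1 `C=CCCCCOc1cc2ccccc2cc1-c1cnc(OCCCCC=C)n1C` gives 25000 nM and compound 2 `CCCCOc1ncc(-c2ccccc2OC)n1C` gives 39000 nM. Among the compounds with values here, these two values lie within the usual scatter of each other, so compound 2 stands level with compound 1 on the numbers so far. Within the data shown here, the two compounds differ in more than one place, so no measured step offers a direct guide to the next compound. Compound 3 `CCCCCCOc1ncc(-c2ccccc2OC)n1C` keeps the core of compound 2 and changes only the chain: ethyl in place of hydrogen on a saturated chain carbon, four bonds along the chain from an oxygen on an aromatic ring. A modest gain in this assay is expected, with a lower number and a step that may not clear the scatter by much, estimated as a 1.8-fold lower number from compound 2 to compound 3 (0.25 log units; within the scatter). Compound 3 is expected at about 22000 nM, with an estimated range of 9000 nM to 50000 nM.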

Compound 3, half-maximal inhibitory concentration: 27000 nM
Compound 3: the middle estimate sits 1.2-fold (0.09 log units) below what was measured, and the stated range covers the measured number.
By their numbers in this assay, from the lowest: compounds 1, 3 and 2 (each within the scatter of the next).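

In this assay, within the data shown here, ethyl in place of hydrogen on a saturated chain carbon, four bonds along the chain from an oxygen on an aromatic ring, gives a 1.4-fold lower number from compound 2 to compound 3 (0.16 log units; within the scatter) and so provides the first direct reading at this position. On this single step, the added ethyl leaves compound 3 indistinguishable from compound 2, so the change shows no measurable effect on the read-out in this cell assay. No measurement available here accounts for this result.

From the compounds shown here alone, whether a longer chain at this position, or an amine or a carboxylic acid in place of the ethyl, would give a step beyond the scatter remains open. Among these compounds, compound 1 differs from the other two compounds in more than one place, so it offers no step to set against this one.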